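Adding a Methyl to the Amine Nitrogen Across Two Cores

The compounds below may be only part of what the source reports. "The series", "measured", "known", "first", "only" and "open" are said of these compounds alone.

Four compounds share the same atoms and differ in two respects: how the fused ring part is joined together, and whether the amine nitrogen at the end of the side chain carries a hydrogen or a methyl. Compound 1 `COc1ccc(C(=O)c2ccc(OC)c3c2OC(C)(C)C=C3)c(NC(=O)CN)c1` serves as the reference point. In a functional assay on MCF7 cells (Homo sapiens) for antiproliferative activity, read by MTT assay, with a stated time of 48 h (on this read-out higher numbers stand for weaker inhibition and lower numbers for stronger inhibition), compound 1 gives 410 nM. Compound 3 `CNCC(=O)Nc1cc(OC)ccc1C(=O)c1ccc(OC)c2c1OC(C)(C)C=C2` differs from compound 1 by a single change, (methyl in place of hydrogen on an amine nitrogen). In this assay compound 3 gives 820 nM, so the step measured was a 2.0-fold higher number from compound 1 to compound 3 (0.30 log units; within the scatter).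

Compound 2 `COc1ccc(C(=O)c2ccc(OC)c3c2C=CC(C)(C)O3)c(NC(=O)CN)c1` has the same atoms as compound 1 joined differently; the difference between the two cores is not broken down here. In this assay, among the compounds with values here, compound 2 gives 1250 nM, the highest of the three numbers so far, beyond the scatter against compound 1 but within it against compound 3.

Compound 4 `CNCC(=O)Nc1cc(OC)ccc1C(=O)c1ccc(OC)c2c1C=CC(C)(C)O2` stands to compound 2 as compound 3 stands to compound 1: the change is methyl in place of hydrogen on an amine nitrogen, and the place is described in the same words in both pairs, so this is the same change. Within the data shown here, because the one measured instance of it gave a 2.0-fold higher number from compound 1 to compound 3 (0.30 log units; within the scatter), the step expected for compound 4 is a 1.8-fold higher number from compound 2 to compound 4 (0.25 log units; within the scatter). On that basis compound 4 is estimated to give about 2200 nM, with a likely range from 900 nM to 5500 nM.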

Compound 4, half-maximal inhibitory concentration: 3040 nM
Compound 4: middle estimate off by 1.4-fold (0.14 log units), on the low side; measured number inside the range.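

In this assay, methyl in place of hydrogen on the amine nitrogen of compound 2 gives a 2.4-fold higher number from compound 2 to compound 4 (0.39 log units; beyond the scatter), and the same change gave a step of similar size on the other core: the same change on two cores in this assay, a 2.0-fold higher number (0.30 log units; within the scatter) from compound 1 to compound 3 and a 2.4-fold higher number (0.39 log units; beyond the scatter) from compound 2 to compound 4, 1.2-fold (0.08 log units) apart, within the scatter of two such steps. Within this small set, the step measured on one core was therefore a fair guide to the step on the other, and the direction was the same in both pairs, with the methyl compound giving the higher number, which here means weaker inhibition; taken alone, only the step on the core of compound 2 lies beyond the scatter, so the agreement between the two steps is better supported than the size of either one. This does not show that the change would behave the same way on a third core, and two pairs of compounds in one cell assay say nothing about why the number rises.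

The compounds shown leave open how a larger group on this nitrogen, such as an ethyl or a second methyl, would compare with the methyl. They also leave open whether a longer chain in place of the aminomethyl would follow the same pattern on both cores.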